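A Sulfonyl Group Added to an Unmeasured Parent

This account rests on a few compounds, and the source may have more. Where it says the series, first, only, none or still open, it means among the compounds named here.

Measured in a functional assay on A549 cells (Homo sapiens) for antiproliferative activity, read by MTT assay, with a stated time of 72 h; a higher number here means a weaker inhibitor, a lower number a stronger inhibitor:
compound 1 `CN1CCN(c2ccc(Nc3ncc4nc(Nc5ccc(F)cc5)n([C@H]5CCCN(S(=O)(=O)C6CC6)C5)c4n3)cc2)CC1`: 1320 nM
compound 2 `CN1CCN(c2ccc(Nc3ncc4nc(Nc5ccccc5)n([C@H]5CCNC5)c4n3)cc2)CC1`: "not determined" (no result reported)
compound 3 `CN1CCN(c2ccc(Nc3ncc4nc(Nc5ccc(F)cc5)n([C@H]5CCNC5)c4n3)cc2)CC1`: "not determined" (no result reported)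

Compound 2 has no place on the numeric scale: no result was reported for it, and the same holds for compound 3. Compound 4 `CN1CCN(c2ccc(Nc3ncc4nc(Nc5ccccc5)n([C@@H]5CCN(S(=O)(=O)C6CC6)C5)c4n3)cc2)CC1` has not yet been measured. The structural change is 1-(cyclopropylsulfonyl)pyrrolidin-3-yl in place of pyrrolidin-3-yl on an aromatic nitrogen, which puts 1-(cyclopropylsulfonyl)pyrrolidin-3-yl in place of pyrrolidin-3-yl on an aromatic nitrogen.

Without a starting number, the size and direction of this step in this assay cannot be read directly. Going by the values given here, the only available anchor is compound 1, which also carries a cyclopropylsulfonyl group, although it differs from compound 4 elsewhere. Compound 1 gives 1320 nM, so compound 4 is expected to land near it, with no gap beyond the usual scatter, though this rests on one value. For compound 4 the estimated value is 1200 nM, with an expected range of 350 nM to 4000 nM.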

Compound 4, half-maximal inhibitory concentration: 2910 nM
Beside the measured number, compound 4's estimate is 2.4-fold (0.38 log units) below it, and the stated range covers the measured number.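

Going by these compounds alone, compound 2 has no number in this assay, and no step to compound 4 can be read from it. The compounds shown leave open how 1-(cyclopropylsulfonyl)pyrrolidin-3-yl in place of pyrrolidin-3-yl changes activity on these cells. No further data shown here bear on this result.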